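Stepping from Sulfonamide to Phenol on a Shared Core

The compounds below may be only part of what the source reports. "The series", "measured", "known", "first", "only" and "open" are said of these compounds alone.

Of the compounds shown here, three built on one shared core have been measured in a functional assay on PC-6 cells (Homo sapiens) for cytotoxicity, read by MTT assay, with a stated time of 3 days; on this read-out higher numbers stand for weaker inhibition and lower numbers for stronger inhibition. Compound 1 `CN(C)Cc1cccc(/C=N/Nc2ncnc3sc(C(C)(C)C)cc23)n1` gives 0.381 ug/mL, compound 2 `CN(C)Cc1ccc(/C=N/Nc2ncnc3sc(C(C)(C)C)cc23)cc1` gives 0.107 ug/mL, and compound 3 `CN(C)S(=O)(=O)c1ccc(/C=N/Nc2ncnc3sc(C(C)(C)C)cc23)cc1` gives 2.12 ug/mL. Compound 3 therefore stands at the highest number of the three, with compound 1 nearest to it and compound 2 furthest away. Going by the values given here, the only single-point step among the measured compounds is the exchange of (dimethylamino)methyl for dimethylsulfamoyl, which brought a 20-fold higher number from compound 2 to compound 3 (1.30 log units; beyond the scatter).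

Compound 4 `CC(C)(C)c1cc2c(N/N=C/c3ccc(O)cc3)ncnc2s1` differs from compound 3 in one place: hydroxy in place of dimethylsulfamoyl on an aromatic carbon. Among the compounds with values here, no measured step involves hydroxy, so the only guidance is that compound 3, carrying dimethylsulfamoyl, gives the weakest result of the three, and that putting that group in place of (dimethylamino)methyl cost a great deal. Removing dimethylsulfamoyl again in favour of a single-atom group is therefore expected to move the number downward in this assay, though how far cannot be read from three compounds, and a step of any size between none and the full reversal remains possible. Compound 4 is estimated at 0.6 ug/mL, within a range from 0.12 ug/mL to 3 ug/mL, which amounts to an expected step of a 3.5-fold lower number from compound 3 to compound 4 (0.55 log units; beyond the scatter).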

Compound 4, half-maximal inhibitory concentration: > 10 ug/mL
Compound 4: only a limit was reported; the forecaster's own chance of this, stated with the estimate: 5%; middle value at least 16-fold (1.22 log units) from the limit.
By their numbers in this assay, from the lowest: compound 2; then compound 1; then compound 3. At a limit, above all of these: compound 4.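

In this assay compound 4 is reported only as a limit, not as a number: the limit of > 10 ug/mL in this assay, at which 1 of the 4 values shown sits. The exchange of dimethylsulfamoyl for hydroxy on this aromatic carbon, para to a large group, therefore does not win back what was lost on leaving (dimethylamino)methyl, and instead moves the number further the same way, with an at least 4.7-fold higher number from compound 3 to compound 4 (0.67 log units; beyond the scatter). Set against the (dimethylamino)methyl group directly, the change is larger, with an at least 93-fold higher number from compound 2 to compound 4 (1.97 log units; beyond the scatter), so at this position a group of 1 heavy atom and one of 6 heavy atoms both give higher numbers than (dimethylamino)methyl, and shrinking the group does not by itself bring the number down.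

What the compounds shown leave open is whether the low number of compound 2 depends on the dimethylamino nitrogen, on the methylene link that holds it, or on both, which a primary aminomethyl group, a dimethylaminoethyl chain or a plain ethyl group at this place could separate. They also leave open whether capping the hydroxy as methoxy, or replacing it with a carboxylic acid, would give a readable number in this assay.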